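Thiophene in place of furan on the saturated carbon of compound 3

The source may report more compounds than this note shows. Statements on the series, on what has been measured and on what is new or still open speak of the compounds shown alone.

Compound 3 `CC1=C(C(=O)C2CC2)C(c2ccoc2)NC(=O)N1` gives 10% in an assay on membranes from HEK293 cells for displacement of a labelled ligand from adenosine receptor A2b (Homo sapiens), read by scintillation counting, with a stated time of 30 min, tested at 1 uM; a lower number here means less inhibition, a higher number more inhibition at the concentration tested (going by the name of the read-out). Among the three measured numbers it sits at the low end: compound 1 `COC(=O)C1=C(C)NC(=O)NC1c1cccs1` gives 19% in this assay, a gap within the scatter, and compound 2 `CC1=C(C(=O)OC(C)(C)C)C(c2cccs2)NC(=O)N1` gives 38%, a gap beyond it. Among the measured compounds shown here, the only measured step, a number 19 percentage points higher from compound 1 to compound 2 (beyond the scatter), concerns the ester and not the aromatic ring, so no measured step bears directly on the change to compound 4 `CC1=C(C(=O)C2CC2)C(c2cccs2)NC(=O)N1`: thiophen-2-yl in place of furan-3-yl on a saturated ring carbon. Compound 1 carries the same thiophen-2-yl ring and gives 19%, so only a small step is expected, a number 7 percentage points higher from compound 3 to compound 4 (within the scatter), not beyond the scatter. Compound 4 is therefore expected to give 17%, with a range from 5% to 32%.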

Compound 4, a percentage reported as inhibition, at one concentration (the size of the read-out at that concentration, not a potency): 1%
The estimate for compound 4 lay 16 percentage points above the measured number; the whole stated range lies above it.
By their numbers in this assay, from the lowest: compounds 4, 3 and 1 (each within the scatter of the next, the first and the last beyond it); then compound 2.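

In this assay, thiophen-2-yl in place of furan-3-yl on the saturated ring carbon is a number 9 percentage points lower from compound 3 to compound 4 (within the scatter) and so does not separate these two cyclopropylcarbonyl compounds. Among the compounds shown, the larger changes lie on the carbonyl carbon: cyclopropyl in place of tert-butoxy is a number 37 percentage points lower from compound 2 to compound 4 (beyond the scatter) and cyclopropyl in place of methoxy is a number 18 percentage points lower from compound 1 to compound 4 (beyond the scatter). No evidence is at hand to explain these steps.

Open, going by these compounds, is how an amine or a longer alkyl chain on the carbonyl carbon would read. Also open, on these data alone, is whether a phenyl ring on the saturated ring carbon would change the number.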